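Methyl for chloro on two related lipoxygenase inhibitor cores

This account rests on a few compounds, and the source may have more. Where it says the series, first, only, none or still open, it means among the compounds named here.

Of the compounds shown here, three have been measured in an assay on RBL-1 cells for inhibition of Polyunsaturated fatty acid 5-lipoxygenase (Rattus norvegicus); on this read-out lower numbers stand for stronger inhibition and higher numbers for weaker inhibition. Compound 1 `Cc1cccc(N2CC(C)NC(=O)N2)n1` gives 3800 nM in this assay, and compound 2 `CC1CN(c2cccc(Cl)n2)NC(=O)N1` gives 3500 nM. Compound 1 differs from compound 2 by one change, (methyl in place of chloro on an aromatic carbon), and the step it made is a 1.1-fold higher number from compound 2 to compound 1 (0.04 log units; within the scatter). Compound 3 `CC1CN(c2cccc(Cl)c2)NC(=O)N1O` gives 3900 nM; how its core differs from the core of compound 2 is not broken down here.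

Compound 4 `Cc1cccc(N2CC(C)N(O)C(=O)N2)c1` has not yet been measured in this assay. It differs from compound 3 by methyl in place of chloro on an aromatic carbon. This is the same kind of change as that from compound 2 to compound 1, but not the same: there the change sat on a six-membered aromatic ring with one nitrogen, next to the ring nitrogen and meta to a group of 8 heavy atoms, whereas here it sits on a six-membered aromatic ring of carbon only, meta to a group of 9 heavy atoms. Because the earlier step of a 1.1-fold higher number from compound 2 to compound 1 (0.04 log units; within the scatter) stayed within the scatter, compound 4 is expected to show a step of no change at the digits printed from compound 3 to compound 4 (within the scatter) from compound 3. On that basis compound 4 is estimated at 3900 nM in this assay, with a range from 1900 nM to 8000 nM.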

Compound 4, half-maximal inhibitory concentration: 8400 nM
For compound 4 the middle estimate is 2.2-fold (0.33 log units) below the measured one, outside the stated range (above it).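

In this assay methyl in place of chloro on the ring of carbon only gives a 2.2-fold higher number from compound 3 to compound 4 (0.33 log units; beyond the scatter) and so counts as a modest step, whereas the same swap on the ring with one nitrogen stayed within the scatter. That contrast alone does not show that the change acts differently on the two cores, and two pairs are too few to show that its effect carries over unchanged from one core to another in this series. Set side by side, the two steps do not separate: the same change on two cores in this assay, a 1.1-fold higher number (0.04 log units; within the scatter) from compound 2 to compound 1 and a 2.2-fold higher number (0.33 log units; beyond the scatter) from compound 3 to compound 4, 2.0-fold (0.30 log units) apart, within the scatter of two such steps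

The compounds shown leave open how an ethyl, a methoxy, a trifluoromethyl or an amine in place of the chloro would read on either core. They also leave open whether any real gap between the two steps would follow the ring that carries the change or some other difference between the two cores.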